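Homologating the ether linker of an EP3 cinnamic acid ligand

The compounds below may be only part of what the source reports. "The series", "measured", "known", "first", "only" and "open" are said of these compounds alone.

Measured so far:
- compound 1 `O=C(O)/C=C/c1ccc(Cn2cccn2)cc1OCCc1ccc2ccccc2c1`, in an assay on CHO cells for displacement of a labelled ligand from prostaglandin E2 receptor EP3 subtype (Mus musculus), read by scintillation counting (on this read-out lower numbers stand for stronger inhibition and higher numbers for weaker inhibition), compound 1 gives 12 nM
- compound 2 `COc1ccc(/C=C/C(=O)O)c(OCCC2(C)CCc3c(C)c(O)c(C)c(C)c3O2)c1`, for compound 2 this assay reports only a limit, > 10000 nM
- compound 3 `O=C(O)/C=C/c1ccc(Cn2ccnc2)cc1OCCCOc1ccccc1`, in this assay compound 3 gives 280 nM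

Of the compounds shown here, three sharing the cinnamic acid core have been measured, and one of them, compound 2, sits at the limit of the assay (the limit of > 10000 nM in this assay, at which 1 of the 3 values shown sits), so it offers no number to compare. Of the two remaining numbers, compound 3 holds the higher one, and compound 1 holds the lower one, a gap that lies beyond the usual scatter.

Compound 4 `O=C(O)/C=C/c1ccc(Cn2ccnc2)cc1OCCCCOc1ccccc1` has not been measured. It differs from compound 3 in one place: phenoxymethyl in place of phenoxy on a saturated chain carbon, three bonds along the chain from an oxygen on an aromatic ring. For the measured compounds named here, no step of this kind is available among the measured compounds, so the expectation is a step of a 1.1-fold higher number from compound 3 to compound 4 (0.03 log units; within the scatter) of no particular direction and not beyond the scatter. Compound 4 is therefore estimated at 300 nM, with a range from 70 nM to 1300 nM.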

Compound 4, inhibition constant: 220 nM
Compound 4: middle estimate off by 1.4-fold (0.13 log units), on the high side, and the stated range covers the measured number.
By their numbers in this assay, from the lowest: compound 1; then compounds 4 and 3 (each within the scatter of the next). At a limit, above all of these: compound 2.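

In this assay, for the compounds shown here, phenoxymethyl in place of phenoxy on a saturated chain carbon, three bonds along the chain from an oxygen on an aromatic ring, gives a 1.3-fold lower number from compound 3 to compound 4 (0.10 log units; within the scatter) and so provides the first step that can be read at this position. Until now, this position had a single value and no comparison. Within the scatter, compound 3 and compound 4 cannot be told apart, so this one change in chain length leaves the read-out effectively unchanged.

From the compounds shown here alone, it remains open whether a longer chain, such as 2-phenoxyethyl, or an amine in place of the chain oxygen would also leave the number within the scatter of these two compounds. The evidence at hand offers nothing that bears on this result.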